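Piperidin-1-yl to 2-oxo-1,3-oxazolidin-3-yl: compound 1 to compound 4

The source may hold more compounds than are shown below. What is called first, only, known or untested is meant among the compounds shown, and "the series" means these compounds.

In a functional assay on aorta (Rattus norvegicus, strain Sprague-Dawley) (on this read-out higher numbers stand for an effect only at larger amounts of compound and lower numbers for an effect already at smaller amounts), compound 1 `Cc1nn(-c2ccccc2)c2nc(OCc3ccccc3F)c(-c3nc(N)c(N4CCCCC4)c(N)n3)cc12` gives 790 nM. Compound 2 `Cc1nn(-c2ccccc2)c2nc(OCc3ccccc3F)c(-c3nc(N)c(N)c(N)n3)cc12` gives 960 nM, and the two sit level within the scatter at the low end of the numbers in hand. Compound 3 `Cc1nn(-c2ccccc2)c2nc(OCc3ccccc3F)c(-c3nc(N)c(NC(=O)OC4CCCC4)c(N)n3)cc12` gives > 100000 nM, which is a limit of this assay and not a number.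

Compound 4 `Cc1nn(-c2ccccc2)c2nc(OCc3ccccc3F)c(-c3nc(N)c(N4CCOC4=O)c(N)n3)cc12` keeps the core of compound 1 and changes one group, with 2-oxo-1,3-oxazolidin-3-yl in place of piperidin-1-yl on an aromatic carbon.

Among the compounds with values here, three measured steps touch this same place. Amino in place of piperidin-1-yl changes nothing beyond the scatter, a 1.2-fold higher number from compound 1 to compound 2 (0.08 log units; within the scatter). The other two steps are large: an at least 120-fold higher number from compound 1 to compound 3 (2.10 log units; beyond the scatter) and an at least 100-fold higher number from compound 2 to compound 3 (2.01 log units; beyond the scatter). Compound 4, like compound 3, has a carbonyl on the nitrogen at this place, but it carries no cyclopentyl. A rise is therefore expected in this assay, beyond the scatter but smaller than the large step of an at least 120-fold higher number from compound 1 to compound 3 (2.10 log units; beyond the scatter). Within the data shown here, no measured compound has the new ring, so the range stays wide.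

The expected step is a 5.1-fold higher number from compound 1 to compound 4 (0.70 log units; beyond the scatter), towards higher numbers. For compound 4 the estimated value is 4000 nM, with an expected range of 500 nM to 60000 nM.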

Compound 4, half-maximal effective concentration: > 100000 nM
Compound 4: a limit, no number (the forecaster's own chance of this, stated with the estimate: 20%); at least 25-fold (1.39 log units) between middle value and limit.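

In this assay compound 4 gives > 100000 nM, which is a limit of the assay and not a number. Both steps into the new ring are large, an at least 120-fold higher number from compound 1 to compound 4 (2.10 log units; beyond the scatter) and an at least 100-fold higher number from compound 2 to compound 4 (2.01 log units; beyond the scatter), so the loss seen with compound 3 does not depend on a cyclopentyl group. At this place, on the aromatic carbon ortho to two amino groups, compound 1 and compound 2 sit level within the scatter, while both compounds with a carbonyl on the attached nitrogen, compound 3 and compound 4, give no number, and the steps between those two cannot be read because both stand at the same ceiling: the limit of > 100000 nM in this assay, at which 2 of the 4 values shown sit.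

From the compounds shown here alone, whether the carbonyl is what goes with this loss stays open, since the carbamate of compound 3 and the ring of compound 4 both carry the carbonyl together with an oxygen on it. Morpholin-4-yl, a ring with oxygen and no carbonyl, and acetylamino, a carbonyl with no ring and no oxygen on it, would pull these features apart on the core of compound 1.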